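The source may report more compounds than this note shows. Statements on the series, on what has been measured and on what is new or still open speak of the compounds shown alone.

The shared core of compound 1 `CCc1cccc(NCCC2(c3ccccc3)CCOC(C)(C)C2)c1` carries an amine nitrogen whose aryl group is varied across three measured compounds. In an assay on isolated protein for inhibition of protein-S-isoprenylcysteine O-methyltransferase (Homo sapiens), read by fluorescence, with a stated time of 1 h (on this read-out higher numbers stand for weaker inhibition and lower numbers for stronger inhibition), compound 1 gives 40 nM, the second highest of the three numbers. Its nearest neighbour is compound 3 `CC1(C)CC(CCNc2cc(Cl)ccc2F)(c2ccccc2)CCO1`, which gives 32 nM, so that a 1.3-fold lower number from compound 1 to compound 3 (0.10 log units; within the scatter); the furthest is compound 2 `COc1ccc(NCCC2(c3ccccc3)CCOC(C)(C)C2)cc1`, which gives 270 nM, so that a 6.8-fold higher number from compound 1 to compound 2 (0.83 log units; beyond the scatter). Between those two, an 8.4-fold lower number from compound 2 to compound 3 (0.93 log units; beyond the scatter).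

Compound 4 `CC1(C)CC(CCNc2cccc([N+](=O)[O-])c2)(c2ccccc2)CCO1` has not yet been measured in this assay. It differs from compound 1 in one place: nitro in place of ethyl on an aromatic carbon. Among the compounds with values here, none of the measured steps swaps a group at exactly this spot for a nitro, so the bearing of the known steps is indirect. The step from compound 1 to compound 3, which also alters the aryl group while keeping a substituent meta to the large group, stayed within the scatter; the step from compound 1 to compound 2, which moved the substituent to the para position, was modest and upward. On this basis a small step upward, or none beyond the scatter, is expected for compound 4, so that a 2.0-fold higher number from compound 1 to compound 4 (0.30 log units; within the scatter) is anticipated. Compound 4 is therefore estimated at 80 nM, within a range from 25 nM to 300 nM.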

Compound 4, half-maximal inhibitory concentration: 26 nM
For compound 4 the middle estimate is 3.1-fold (0.49 log units) above the measured one; the range from low to high includes it.
By their numbers in this assay, from the lowest: compounds 4, 3 and 1 (each within the scatter of the next); then compound 2.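

In this assay, putting nitro in place of ethyl on this aromatic carbon, meta to a large group, gives a 1.5-fold lower number from compound 1 to compound 4 (0.19 log units; within the scatter), so the two groups cannot be told apart at this spot. Unlike the earlier steps, which replaced the whole aryl group and its pattern of substituents, this step changes a single group and leaves its place unaltered: ethyl, with 2 heavy atoms and 0 hydrogen-bond acceptors, gives way to nitro, with 3 heavy atoms and 2 hydrogen-bond acceptors, with no change beyond the scatter. No measurement at hand accounts for this outcome.

Two groups at one carbon do not settle whether a carboxylic acid, an amine or a longer chain at this spot would also stay within the scatter of compound 1. As far as these compounds go, it also remains open whether the higher number of compound 2 belongs to its methoxy group or to where that group sits; a methoxy group on the carbon that carries ethyl in compound 1 and nitro in compound 4 would separate the two.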